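The source may hold more compounds than are shown below. What is called first, only, known or untested is meant among the compounds shown, and "the series" means these compounds.

Measured compounds in an assay on isolated protein for inhibition of DNA topoisomerase 1 (Homo sapiens), with a stated time of 30 min, tested at 100 uM; on this read-out higher numbers stand for a stronger effect at the one concentration tested and lower numbers for a weaker effect:
- compound 1, `Oc1ccc(-c2cc(-c3cccs3)cc(-c3ccc(O)cc3)n2)cc1`: 86.3%
- compound 2, `Oc1ccc(-c2cc(-c3ccsc3)cc(-c3ccccc3O)n2)cc1`: 13.8%
- compound 3, `Oc1ccc(-c2cc(-c3ccsc3)cc(-c3cccc(O)c3)n2)cc1`: 17.1%

Compound 3 stands second of the three numbers in this assay. Its nearest neighbour is compound 2, whose value lies within the scatter of it; the step of a number 3.3 percentage points higher from compound 2 to compound 3 (within the scatter) therefore shows no real difference between a 2-hydroxyphenyl and a 3-hydroxyphenyl group on the shared core. Compound 1, at the other end, lies far beyond the scatter above compound 3.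

Compound 4, `Oc1ccc(-c2cc(-c3ccsc3)cc(-c3ccc(O)cc3)n2)cc1`, is not yet measured. It differs from compound 3 in one place: 4-hydroxyphenyl in place of 3-hydroxyphenyl on an aromatic carbon.

For the measured compounds named here, only one measured step bears directly on moving a hydroxyl around the phenyl ring, and that step was within the scatter. Going by the values given here, no step isolates the move from 3-hydroxyphenyl to 4-hydroxyphenyl. Compound 1 carries a 4-hydroxyphenyl group at the same place and gives a high value, but it also bears a thiophen-2-yl rather than a thiophen-3-yl group, so its number cannot be read as a clean guide. The expected step of a number 32.9 percentage points higher from compound 3 to compound 4 (beyond the scatter) is therefore upward, but the estimate is uncertain and the range wide.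

For compound 4 the expected value in this assay is 50%, within 15% to 85%.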

Compound 4, a percentage reported as inhibition, at one concentration (the size of the read-out at that concentration, not a potency): 61.7%
Beside the measured number, compound 4's estimate is 11.7 percentage points below it; measured number inside the range.
By their numbers in this assay, from the lowest: compounds 2 and 3 (each within the scatter of the next); then compound 4; then compound 1.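

In this assay, the position of the hydroxyl on the phenyl group next to the ring nitrogen turns out to matter, but only for the 4-hydroxyphenyl group: moving it there gives a number 44.6 percentage points higher from compound 3 to compound 4 (beyond the scatter) and, from the 2-hydroxyphenyl group, a number 47.9 percentage points higher from compound 2 to compound 4 (beyond the scatter) on the thiophen-3-yl series. The earlier 2-hydroxyphenyl to 3-hydroxyphenyl step had stayed within the scatter, so among these three groups the read-out separates the 4-hydroxyphenyl group from the other two, with no gradual change across the ring. With the 4-hydroxyphenyl group held fixed, the thiophene attachment can now be read on its own and also counts, though as a modest step: a number 24.6 percentage points lower from compound 1 to compound 4 (beyond the scatter) in this pair.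

Going by these compounds, it remains open whether the thiophen-2-yl group would give the same dependence on hydroxyl position, whether a 4-methoxyphenyl or 4-aminophenyl group at this place would hold the read-out, and whether the stronger and weaker effects seen at this one concentration would keep their order at other concentrations. Nothing available accounts for why the 4-hydroxyphenyl group stands apart from the other two groups.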